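From Compound 3 to Compound 4 in a Cell Growth Assay

This account rests on a few compounds, and the source may have more. Where it says the series, first, only, none or still open, it means among the compounds named here.

Of the compounds shown here, three have so far been measured in a functional assay on MCF7 cells (Homo sapiens) for inhibition, read by MTT assay, with a stated time of 48 h, tested at 10 uM; on this read-out lower numbers stand for less inhibition of growth and higher numbers for more inhibition of growth at the one concentration tested. Compound 1 `Cc1cc(=O)c2c(O)cc(OC/C=C/c3ccccc3)c([C@H]3CCN(C)C[C@H]3O)c2o1` gives 7%, compound 2 `Cc1cc(=O)c2c(O)c(CN3CCCCC3)c(O)c([C@H]3CCN(C)C[C@H]3O)c2o1` gives 15%, and compound 3 `Cc1oc2c([C@H]3CCN(C)C[C@H]3O)c(O)cc(O)c2c(=O)c1C(O)c1ccc(Cl)cc1` gives 6%. Compound 3 carries the lowest of the three numbers, yet its gaps to compound 1 and to compound 2 both lie within the scatter, so no order among the three can be claimed. Compound 4 `CCOc1ccc(Br)c(C(O)c2c(C)oc3c([C@H]4CCN(C)C[C@H]4O)c(O)cc(O)c3c2=O)c1` has not yet been measured. It differs from compound 3 by 2-bromo-5-ethoxyphenyl in place of 4-chlorophenyl on a saturated chain carbon bound to an aromatic carbon and an oxygen on a saturated carbon. Among the compounds with values here, no step between measured compounds covers a change of this kind, and all three measured numbers sit close together, so the expected step of a number 3 percentage points higher from compound 3 to compound 4 (within the scatter) is none beyond the scatter. Compound 4 is accordingly estimated at 9%, with a range from 0% to 25%.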

Compound 4, percent growth inhibition at one concentration: 9%
Compound 4: middle estimate and measured number agree at the digits printed, and the stated range covers the measured number.
By their numbers in this assay, from the lowest: compounds 3, 1, 4 and 2 (each within the scatter of the next).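

In this assay, within the data shown here, 2-bromo-5-ethoxyphenyl in place of 4-chlorophenyl on a saturated chain carbon bound to an aromatic carbon and an oxygen on a saturated carbon gives a number 3 percentage points higher from compound 3 to compound 4 (within the scatter) and is the first step read at this position. Exchanging one substituted phenyl for the other, with one hydrogen-bond acceptor entering, therefore yields no change separable from the scatter. No measurement shown here bears on this result.

On these data alone, whether a group without a phenyl ring at this place, such as an amine or a carboxylic acid, would shift the number remains open.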